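Series notes: step from compound 3 to compound 4

A few compounds are considered here, and "the series" means these few. Any claim that something is new, unique, unknown or untested is made for them only; others in the source may bear on it.

Measured so far in a functional assay on Hep 3B2 cells (Homo sapiens) for antiproliferative activity, read by MTT assay, with a stated time of 24 h, tested at 100 ug/mL; a higher number here means a stronger effect of the compound at the concentration tested, a lower number a weaker effect:
compound 1, `Cc1c(C(=O)Nc2c(F)cc(-c3cccc(F)c3)cc2F)nc2ccc(OC(F)(F)F)cc2c1O`, gives 80.3%
compound 2, `Cc1c(C(=O)Nc2c(F)cc(-c3cccc(F)c3)cc2F)nc2ccc(C(F)(F)F)cc2c1O`, gives 68.4%
compound 3, `COc1ccc2nc(C(=O)Nc3ccc(-c4ccccc4)cc3)c(C)c(O)c2c1`, gives 79.3%

Compound 3 stands second highest of the three numbers. Its nearest neighbour is compound 1, whose value is within the scatter of that of compound 3; compound 2 lies beyond the scatter, below compound 3. Among the measured compounds shown here, the one step between measured compounds that differ in a single place is a number 11.9 percentage points lower from compound 1 to compound 2 (beyond the scatter), where trifluoromethyl takes the place of trifluoromethoxy on an aromatic carbon.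

Compound 4, `Cc1c(C(=O)Nc2ccc(-c3ccccc3)cc2)nc2ccccc2c1O`, is not yet measured. It differs from compound 3 as follows: hydrogen in place of methoxy on an aromatic carbon. For the measured compounds named here, no measured pair shows a hydrogen in place of a methoxy, so no step bears directly on this change. The step from compound 1 to compound 2 is the only one on record for a change at an aromatic carbon of the shared core; it is modest and involves different groups, so it gives only a loose guide. Compound 4 is therefore expected to sit close to compound 3, with no more than a modest drop: the expected step is a number 7.3 percentage points lower from compound 3 to compound 4 (within the scatter). The estimate for compound 4 in this assay is 72%, between 55% and 88%.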

Compound 4, a percentage reported as inhibition, at one concentration (the size of the read-out at that concentration, not a potency): 84.3%
Compound 4: middle estimate off by 12.3 percentage points, on the low side; measured number inside the range.
By their numbers in this assay, from the lowest: compound 2; then compounds 3, 1 and 4 (each within the scatter of the next).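

In this assay, a number 5 percentage points higher from compound 3 to compound 4 (within the scatter) shows that, with this remainder of the molecule, compound 3 and compound 4 cannot be told apart when methoxy gives way to hydrogen on this aromatic carbon, para to a fused ring. Among the compounds shown here, the methoxy is therefore not needed for a read-out of this size at the single concentration tested, which the earlier compounds could not show because none of them carried hydrogen at this place. For the compounds shown here, the only other step on an aromatic carbon of the shared core, a number 11.9 percentage points lower from compound 1 to compound 2 (beyond the scatter), exchanges different groups on a different remainder, so the two steps are not read as one trend. Nothing on hand explains the outcome for compound 4.

Still open, on these data alone, is whether an amine, a carboxylic acid or a longer chain such as butoxy at this place would also stay within the scatter of hydrogen and methoxy. As far as these compounds go, it is also open whether the exchange of methoxy for hydrogen would behave the same way on the remainder of compound 1, and whether compound 3 and compound 4 would differ in the strength of their effect at other concentrations.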